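Swapping a Tert-Butylphenyl Group for a Benzodioxinyl Ring

This account rests on a few compounds, and the source may have more. Where it says the series, first, only, none or still open, it means among the compounds named here.

Three sulfonamide-linked amines have been measured in a functional assay on MIA PaCa-2 cells (Homo sapiens) for inhibition, read by MTT assay, with a stated time of 72 h; on this read-out higher numbers stand for weaker inhibition of growth and lower numbers for stronger inhibition of growth. Compound 1 `O=S(=O)(NCCNCc1ccc(-c2ccccc2)cc1)c1cc(C(F)(F)F)cc(C(F)(F)F)c1` gives 2700 nM, compound 2 `CC(C)(C)c1ccc(CNCCCNS(=O)(=O)c2cc(C(F)(F)F)cc(C(F)(F)F)c2)cc1` gives 2300 nM, and compound 3 `CC(C)c1ccc(S(=O)(=O)NCCCCCCNCc2ccc(Br)cc2)cc1` gives 5730 nM. Compound 2 has the lowest number of the three, though compound 1 sits within the scatter of it, while compound 3 lies beyond it.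

Compound 4 `O=S(=O)(NCCCNCC1COc2ccccc2O1)c1cc(C(F)(F)F)cc(C(F)(F)F)c1` has not yet been measured. Compared with compound 2, the change is 2,3-dihydro-1,4-benzodioxin-2-yl in place of 4-(tert-butyl)phenyl on a saturated chain carbon bound to an amine nitrogen. Going by the values given here, no measured pair tells how such a change reads in this assay, so only a cautious expectation is possible: a modest move toward weaker growth inhibition, which may still fall within the scatter. The step of a 1.7-fold higher number from compound 2 to compound 4 (0.24 log units; within the scatter) is therefore expected to be small. On that basis compound 4 is estimated at 4000 nM, with a range from 1500 nM to 12000 nM.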

Compound 4, concentration for 50% growth inhibition: 2600 nM
Compound 4: middle estimate off by 1.5-fold (0.19 log units), on the high side; the measured number falls inside the stated range.
By their numbers in this assay, from the lowest: compounds 2, 4 and 1 (each within the scatter of the next); then compound 3.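

In this assay, the place on a saturated chain carbon bound to an amine nitrogen takes 2,3-dihydro-1,4-benzodioxin-2-yl instead of 4-(tert-butyl)phenyl with a 1.1-fold higher number from compound 2 to compound 4 (0.05 log units; within the scatter) here, so this assay does not separate the two groups. The entering group brings 2 hydrogen-bond acceptors and a non-aromatic ring with 2 hetero atoms, yet the reading stays within the scatter. Nothing available explains this result. Going by these compounds, whether a carboxylic acid or a simple amine at this place would read the same remains open. This single step also cannot show whether the swap would behave alike on a longer chain.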